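This account rests on a few compounds, and the source may have more. Where it says the series, first, only, none or still open, it means among the compounds named here.

Compound 1 `O=C(CSc1nnc(-c2ccncc2)o1)N/N=C/c1ccc([N+](=O)[O-])cc1` is the weaker of the two thiadiazole-free hydrazones measured here only on paper: in a functional assay on SW 1116 cells (Homo sapiens) for cytotoxicity, read by MTT assay, with a stated time of 48 h (a lower number here means a stronger inhibitor, a higher number a weaker inhibitor), compound 1 gives 25800 nM, and its companion compound 2 `Cc1ccc(/C=N/NC(=O)CSc2nnc(-c3ccncc3)o2)cc1` gives 16800 nM in the same assay. Among the measured compounds shown here, the single step between them, a 1.5-fold lower number from compound 1 to compound 2 (0.19 log units; within the scatter), stays within the scatter, so the two cannot be separated on potency. Compound 3 `O=C(CSc1nnc(-c2ccncc2)o1)N/N=C/c1cc(Br)cc(Br)c1O` has not yet been measured; it differs from compound 1 by 3,5-dibromo-2-hydroxyphenyl in place of 4-nitrophenyl on a carbon with a double bond to nitrogen. For the measured compounds named here, the only measured step that bears on this change is the substituent swap from compound 1 to compound 2, and that swap moved nothing beyond the scatter. Going by the values given here, there is no measured example of a hydroxy or bromo group entering at this place, so the expectation rests on that one step alone. For compound 3 the expected step is a 1.3-fold lower number from compound 1 to compound 3 (0.11 log units; within the scatter), with no clear direction beyond the scatter. Compound 3 is therefore estimated at 20000 nM, in a range from 6000 nM to 65000 nM.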

Compound 3, half-maximal inhibitory concentration: 8570 nM
Compound 3: the middle estimate sits 2.3-fold (0.37 log units) above what was measured; low and high end bracket the measured number.
By their numbers in this assay, from the lowest: compounds 3, 2 and 1 (each within the scatter of the next, the first and the last beyond it).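

Among the compounds shown here, the change to 3,5-dibromo-2-hydroxyphenyl on the carbon with a double bond to nitrogen gives a 3.0-fold lower number from compound 1 to compound 3 (0.48 log units; beyond the scatter) in this assay and is the first step to pass beyond the scatter, which the swap of nitro for methyl, with a 1.5-fold lower number from compound 1 to compound 2 (0.19 log units; within the scatter), did not do. Measured against the 4-methylphenyl group, the same change gives a 2.0-fold lower number from compound 2 to compound 3 (0.29 log units; within the scatter), so compound 3 is separated from compound 1 but not from compound 2. No measurement offered here accounts for this step.

The compounds shown leave open whether the hydroxy group alone or the two bromo groups alone would give the same step. They also leave open how an amine or a carboxylic acid on this phenyl ring would read in this assay.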